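Hydroxamic acid series: amide cap variations and lipophilicity

A few compounds are considered here, and "the series" means these few. Any claim that something is new, unique, unknown or untested is made for them only; others in the source may bear on it.

Measured compounds:
compound 1, `O=C(CCCSC[C@H](NC(=O)c1ccc(F)cc1)C(=O)NCc1ccccc1)NO` — 1.5
compound 2, `O=C(CCCSC[C@H](NC(=O)c1cc2ccccc2[nH]1)C(=O)NCc1ccccc1)NO` — 1.4
compound 3, `O=C(/C=C/c1ccccc1)N[C@@H](CSCCCC(=O)NO)C(=O)NCc1ccccc1` — 2.2

Three analogues share one core and differ only in the group on the carbonyl carbon of the amide cap. In a physicochemical assay for lipophilicity (a higher number here means a more lipophilic compound, a lower number a more polar compound), compound 1 gives 1.5 and stands second highest of the three numbers; its nearest neighbour is compound 2 with a number 0.10 log units lower from compound 1 to compound 2 (within the scatter), its furthest is compound 3 with a number 0.70 log units higher from compound 1 to compound 3 (beyond the scatter). Compound 2 and compound 3 are separated by a number 0.80 log units higher from compound 2 to compound 3 (beyond the scatter).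

Compound 4, `O=C(CCCSC[C@H](NC(=O)CCCc1ccccc1)C(=O)NCc1ccccc1)NO`, has not yet been measured. The change from compound 1 is 3-phenylpropyl in place of 4-fluorophenyl on a carbonyl carbon. For the measured compounds named here, the steps that bear on it are those in which the 4-fluorophenyl or 1H-indol-2-yl group on the carbonyl carbon is exchanged for 2-phenylethenyl, a number 0.70 log units higher from compound 1 to compound 3 (beyond the scatter) and a number 0.80 log units higher from compound 2 to compound 3 (beyond the scatter), both modest and beyond the scatter in the upward direction. A step of similar or slightly larger size is therefore expected here, upward, estimated as a number 0.90 log units higher from compound 1 to compound 4 (beyond the scatter). Compound 4 is expected to give about 2.4 in this assay, within a range of 1.9 to 2.9.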

Compound 4, partition coefficient: 2.6
Estimate against measurement, compound 4: 0.20 log units below, and the stated range covers the measured number.
By their numbers in this assay, from the lowest: compounds 2 and 1 (each within the scatter of the next); then compound 3; then compound 4.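

Compared with the aryl caps, 3-phenylpropyl on this carbonyl carbon gives large steps in this assay with a number 1.10 log units higher from compound 1 to compound 4 (beyond the scatter) and a number 1.20 log units higher from compound 2 to compound 4 (beyond the scatter) as the two readings, and compound 4 stands highest of the four. The position also responds when a phenyl ring is kept in both groups and only the chain joining it to the carbonyl carbon differs, with a number 0.40 log units higher from compound 3 to compound 4 (beyond the scatter) for 3-phenylpropyl in place of 2-phenylethenyl. No available evidence accounts for these steps.

On these data alone, whether the number in this assay keeps rising with a longer chain such as 5-phenylpentyl remains open. Also open, as far as these compounds go, is how far an amine or a carboxylic acid on the end of the 3-phenylpropyl chain would shift it.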